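This account rests on a few compounds, and the source may have more. Where it says the series, first, only, none or still open, it means among the compounds named here.

Of the compounds shown here, three sharing a core have been tested in a functional assay on HeLa cells (Homo sapiens) for cytotoxicity, read by MTT assay; on this read-out lower numbers stand for stronger inhibition and higher numbers for weaker inhibition. Compound 1 (`COC(=O)C[C@@H]1C[C@@H](O)[C@H](C)[C@H](c2ccccc2)N1`) gives 6500 nM. Compound 2 (`COC(=O)C[C@H]1C[C@@H](O)[C@@H](C)[C@@H](c2ccc(C(C)C)cc2)N1`) is reported as "not active" (no number reported), whereas compound 3 (`COC(=O)C[C@H]1C[C@H](O)[C@@H](C)[C@@H](c2ccc(C(C)C)cc2)N1`) gives 18200 nM. The contrast between these last two rests on (the fact that compounds 2 and 3 differ only in the configuration as drawn). Among the measured compounds shown here, compound 3 therefore holds the higher of the only two numbers available, and it is weaker than compound 1 by a margin beyond the usual scatter.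

The next compound, compound 4 (`COC(=O)C[C@H]1C[C@H](O)[C@@H](C)[C@@H](c2ccc(OC)cc2)N1`), has not yet been measured. It carries methoxy in place of isopropyl on an aromatic carbon, para to a large group: methoxy in place of isopropyl on an aromatic carbon. For the measured compounds named here, no measured pair shows this exchange on its own, so the expectation starts from compound 3 at 18200 nM, with compound 1 at 6500 nM as the nearest number on the stronger side. The expected change, a 1.2-fold lower number from compound 3 to compound 4 (0.08 log units; within the scatter), is small and stays within the scatter, with only a slight lean towards a lower number in this assay. The result reported as "not active" (no number reported) for compound 2 means that an outcome without a number cannot be ruled out. Compound 4 is expected at 15000 nM, with an estimated range from 5000 nM to 45000 nM.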

Compound 4, half-maximal inhibitory concentration: 5300 nM
Compound 4: the middle estimate sits 2.8-fold (0.45 log units) above what was measured; measured number inside the range.
By their numbers in this assay, from the lowest: compounds 4 and 1 (each within the scatter of the next); then compound 3.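

In this assay, methoxy in place of isopropyl on an aromatic carbon, para to a large group, gives a 3.4-fold lower number from compound 3 to compound 4 (0.54 log units; beyond the scatter), so this position is not indifferent to the group it carries. Among the compounds shown here, the earlier compounds could not show this, since none of their comparisons isolated a change at this place, and this exchange is the first to do so, with a modest step that lies beyond the usual scatter. It also replaces an all-carbon group with one that brings an oxygen and a hydrogen-bond acceptor, but nothing measured here explains why the number falls.

With a single exchange at this position, the compounds shown cannot separate the effect of the oxygen from that of the change in group size, nor tell whether a hydroxy group, an amine or a longer alkoxy chain such as ethoxy would lower the number further or raise it. From the compounds shown here alone, it also remains open whether the same exchange would give a step of similar size in the configuration of compound 2, which has no number to start from.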